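This account rests on a few compounds, and the source may have more. Where it says the series, first, only, none or still open, it means among the compounds named here.

Measured to date in an assay on MDA-MB-231 cells for binding affinity to C-X-C chemokine receptor type 4 (Homo sapiens), read by fluorescence and microscopy, with stated times of 10 min and 30 min; on this read-out higher numbers stand for an effect only at larger amounts of compound and lower numbers for an effect already at smaller amounts:
- compound 1 `CCN(CC)Cc1ccc(S(=O)(=O)NCc2ccc(CNC(=O)c3ccc(F)cc3)cc2)cc1`: 1 nM
- compound 2 `O=C(NCc1ccc(CNS(=O)(=O)c2ccc([N+](=O)[O-])cc2)cc1)c1ccc(F)cc1`: 1000 nM
- compound 3 `O=C(NCc1ccc(CNS(=O)(=O)c2cccc(F)c2)cc1)c1ccc(F)cc1`: 1000 nM

Among the compounds with values here, compound 3 stands level with compound 2 at the digits given; together they hold the highest numbers of the three, and both sit far from compound 1, the single low number in this assay. Within the data shown here, the one large step in the set is a 1000-fold higher number from compound 1 to compound 2 (3.00 log units; beyond the scatter), while the swap at the sulfonyl sulfur gives no change at the digits printed from compound 2 to compound 3 (within the scatter).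

Compound 4 `O=C(NCc1ccc(CNS(=O)(=O)c2ccc(F)c(F)c2)cc1)c1ccc(F)cc1` is not yet measured. It differs from compound 3 by fluoro in place of hydrogen on an aromatic carbon, that is, 3-fluorophenyl to 3,4-difluorophenyl on the sulfonyl sulfur. The step that bears on this is the one at the same position, from compound 2 to compound 3, which lay within the scatter; the step from compound 1 to compound 2 touches a different part of the shared core and does not speak to a second fluoro. The expectation in this assay is therefore no change at the digits printed from compound 3 to compound 4 (within the scatter), no step beyond the scatter. Compound 4 is estimated at 1000 nM, within 300 nM to 3000 nM.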

Compound 4, effective concentration (reported as EC, without a stated level of effect): 10 nM
The estimate for compound 4 lay 100-fold (2.00 log units) above the measured number; the whole stated range lies above it.
By their numbers in this assay, from the lowest: compound 1; then compound 4; then compounds 2 and 3 (each within the scatter of the next).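

In this assay the group on the sulfonyl sulfur proves able to move the number: fluoro in place of hydrogen gives a 100-fold lower number from compound 3 to compound 4 (2.00 log units; beyond the scatter) and 3,4-difluorophenyl in place of 4-nitrophenyl gives a 100-fold lower number from compound 2 to compound 4 (2.00 log units; beyond the scatter) at the same position. The earlier swap here gave no change at the digits printed from compound 2 to compound 3 (within the scatter) and made the position look flat, but a single fluoro, ortho to a fluoro group and para to a large group, shows that it does not stay flat for every change. No measurement on hand gives a reason for this step.

As far as these compounds go, it remains open whether both fluoro groups are needed or whether 4-fluorophenyl alone would give a similar number. Also open, from the compounds shown here alone, is whether chloro or methoxy in place of the added fluoro would give a step of this size.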